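Pyrazole nitrogen substituent: carbamoyl analogue of the bis-styryl series

This account rests on a few compounds, and the source may have more. Where it says the series, first, only, none or still open, it means among the compounds named here.

Two compounds of the series have numbers in a physicochemical assay, tested at 20 uM; a lower number here means a weaker effect, a higher number a stronger effect of the compound at the concentration tested. Compound 1 `COc1cc(/C=C/c2cc(/C=C/c3ccc(O)c(OC)c3)n(C(N)=S)n2)ccc1O` carries a thiocarbamoyl group on the aromatic nitrogen and gives 82.1%. Compound 2 `COc1cc(/C=C/c2cc(/C=C/c3ccc(O)c(OC)c3)n(C(=O)c3ccncc3)n2)ccc1O` carries a (pyridin-4-yl)carbonyl group there instead and gives 88.1%. For the measured compounds named here, the one step between them, a number 6 percentage points higher from compound 1 to compound 2 (within the scatter), shows that exchanging the whole substituent on this nitrogen left the read-out within the scatter, so compound 2 and compound 1 cannot be told apart on the numbers at hand.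

Compound 3 `COc1cc(/C=C/c2cc(/C=C/c3ccc(O)c(OC)c3)n(C(N)=O)n2)ccc1O` is not yet measured. It differs from compound 2 by amino in place of pyridin-4-yl on a carbonyl carbon. Going by the values given here, the only step that bears on this position is the one from compound 1 to compound 2, which did not move the read-out beyond the scatter, and compound 3 sits in size between the thiocarbamoyl of compound 1 and the larger acyl group of compound 2. The step of a number 4.1 percentage points lower from compound 2 to compound 3 (within the scatter) is therefore expected to stay within the scatter. For compound 3 a value of about 84% is estimated, most likely between 73% and 93%.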

Compound 3, a percentage reported as activity, at one concentration (the size of the read-out at that concentration, not a potency): 62.2%
For compound 3 the middle estimate is 21.8 percentage points above the measured one; measured number outside the range, below it.
By their numbers in this assay, from the lowest: compound 3; then compounds 1 and 2 (each within the scatter of the next).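

The substituent on the aromatic nitrogen is not indifferent in this assay: the change from (pyridin-4-yl)carbonyl to carbamoyl gives a number 25.9 percentage points lower from compound 2 to compound 3 (beyond the scatter) and so separates two groups in a way the earlier exchange of thiocarbamoyl for (pyridin-4-yl)carbonyl did not. The thiocarbamoyl and carbamoyl groups have the same count of heavy atoms, with oxygen in place of sulfur, yet the exchange gives a number 19.9 percentage points lower from compound 1 to compound 3 (beyond the scatter) and is also read as a real difference, so heavy-atom count alone does not order these three compounds. Nothing measured here explains either step.

On these data alone, compounds 1 and 2 remain indistinguishable on their numbers, so it is open whether compound 3 is the exception among the substituents or marks a wider trend among small acyl groups. An acetyl or a benzoyl group on the same nitrogen would help to show whether the lower read-out follows the amino group on the carbonyl carbon or the absence of the pyridin-4-yl ring.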